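Cyclohexyl for chlorophenyl on the amide nitrogen

The source may report more compounds than this note shows. Statements on the series, on what has been measured and on what is new or still open speak of the compounds shown alone.

Measured in a functional assay on HepG2 cells (Homo sapiens) for antiproliferative activity, read by MTT assay, with a stated time of 72 h; on this read-out higher numbers stand for weaker inhibition and lower numbers for stronger inhibition:
compound 1 `COc1ccc(N2C(=O)COc3ccc(-c4cnc(OC)c(NS(=O)(=O)c5ccc(F)cc5)c4)cc32)cc1` gives 13100 nM
compound 2 `O=C1COc2ccc(-c3cnc(Cl)c(NS(=O)(=O)c4ccc(F)cc4)c3)cc2N1C1CCCCC1` reaches only the limit of the assay, > 40000 nM
compound 3 `COc1ncc(-c2ccc3c(c2)N(c2ccc(Cl)cc2)C(=O)CO3)cc1NS(=O)(=O)c1ccc(F)cc1` gives 17900 nM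

Compound 3 carries the highest of the two numbers given, with compound 1 nearest to it; the difference a 1.4-fold higher number from compound 1 to compound 3 (0.14 log units; within the scatter) is within the scatter. Compound 2 is represented by a limit rather than a number (the limit of > 40000 nM in this assay, at which 1 of the 3 values shown sits).

Compound 4 `COc1ncc(-c2ccc3c(c2)N(C2CCCCC2)C(=O)CO3)cc1NS(=O)(=O)c1ccc(F)cc1` is not yet measured in this assay. It differs from compound 3 by cyclohexyl in place of 4-chlorophenyl on an amide-type nitrogen in a ring. Among the compounds with values here, no measured step covers this change directly: the one step in hand concerns the methoxy-to-chloro exchange on the aromatic carbon. Compound 2, the other compound bearing cyclohexyl at this position, gives only a limit. The expectation for compound 4 in this assay is therefore a weakening, as a 2.0-fold higher number from compound 3 to compound 4 (0.29 log units; within the scatter), with a real chance that only a limit is returned. Compound 4 is estimated at 35000 nM, within 15000 nM to 80000 nM.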

Compound 4, half-maximal inhibitory concentration: > 40000 nM
Compound 4 ended at the assay's limit; the forecaster's own chance of this, stated with the estimate: 45%; middle value at least 1.1-fold (0.05 log units) away from the limit.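

In this assay, cyclohexyl in place of 4-chlorophenyl on the amide-type nitrogen in a ring costs activity, with an at least 2.2-fold higher number from compound 3 to compound 4 (0.34 log units; beyond the scatter). Cyclohexyl in place of 4-methoxyphenyl points the same way, with an at least 3.0-fold higher number from compound 1 to compound 4 (0.48 log units; beyond the scatter), so at this position both aromatic groups do better than cyclohexyl, while the two aromatic groups themselves stay within the scatter of each other. The step between compound 2 and compound 4 cannot be read, because both compounds end at a limit rather than a number: the limit of > 40000 nM in this assay, at which 2 of the 4 values shown sit.

As far as these compounds go, how much activity cyclohexyl leaves in compound 4 stays unknown, and so does any effect of methoxy against chloro on the aromatic carbon when cyclohexyl is present. Also open, from the compounds shown here alone, is whether a benzyl group or a chain ending in an amine on this nitrogen would keep activity.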